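A few compounds are considered here, and "the series" means these few. Any claim that something is new, unique, unknown or untested is made for them only; others in the source may bear on it.

Measured so far:
compound 1 `C=CCNC(=O)/C(C)=C(\C)c1cc(OC)c(OC)c(OC)c1` — 280 mg/kg
compound 2 `C=CCNC(=O)/C(C)=C(\C)c1ccc(C)cc1` — 170 mg/kg
compound 3 `C/C(C(=O)NC1CC1)=C(/C)c1ccc(Cl)cc1` — > 800 mg/kg

In a toxicity assay on the whole organism (strain Icem-CET (SPF Caw)) for cytotoxicity, with Mus musculus as the target (on this read-out lower numbers stand for an effect already at smaller amounts and higher numbers for an effect only at larger amounts of compound), compound 1 gives 280 mg/kg. Compound 2 gives 170 mg/kg in this assay, and the two numbers lie within the usual scatter of each other, so no order between them can be claimed. The value of compound 3 in this assay is a limit, not a number: the limit of > 800 mg/kg in this assay, at which 1 of the 3 values shown sits.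

Compound 4 `COc1cc(/C(C)=C(\C)C(=O)NC2CC2)cc(OC)c1OC` has not yet been measured in this assay. It keeps the shared core of compound 1 and differs from it in one place: cyclopropyl in place of allyl on an amide-type nitrogen. Within the data shown here, no measured pair shows this exchange on its own. Compound 3, which also carries the cyclopropylcarbamoyl group, reached only a limit, but it differs from compound 1 in more than one place, so its value cannot be read as the size of this step.

For compound 4 the account therefore expects a step from compound 1 of a 1.6-fold higher number from compound 1 to compound 4 (0.21 log units; within the scatter), towards an effect only at larger amounts, with a real chance that the assay again reports a limit. The estimate for compound 4 in this assay is 450 mg/kg, between 200 mg/kg and 1000 mg/kg.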

Compound 4, dose for half-maximal effect: > 800 mg/kg
Compound 4: no number, only a limit (the forecaster's own chance of this, stated with the estimate: 35%); middle value at least 1.7-fold (0.24 log units) from the limit.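

In this assay compound 4 gives > 800 mg/kg, which is a limit and not a number. Among these compounds, with the shared core kept, cyclopropyl in place of allyl on an amide-type nitrogen gives an at least 2.8-fold higher number from compound 1 to compound 4 (0.45 log units; beyond the scatter), so this position responds to the exchange, a step that no earlier pair could show on its own. Compound 3 and compound 4, which both carry the cyclopropylcarbamoyl group, now stand at the same limit: the limit of > 800 mg/kg in this assay, at which 2 of the 4 values shown sit.

On these data alone, since compound 4 has only a limit, the full size of the step stays open, as does whether the same exchange on compound 2 would give a step of like size. Also open, as far as these compounds go, is whether propyl or cyclobutyl on this nitrogen would read like allyl or like cyclopropyl.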